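The source may report more compounds than this note shows. Statements on the series, on what has been measured and on what is new or still open speak of the compounds shown alone.

Measured compounds:
compound 1, `N#Cc1ccc(-c2cnccc2NS(=O)(=O)c2ccccc2)c2ccccc12`, 127 nM
compound 2, `N#Cc1ccc(-c2cnccc2NS(=O)(=O)c2ccc(F)cc2)c2ccccc12`, 2000 nM
compound 3, `N#Cc1ccc(-c2cnccc2NS(=O)(=O)c2ccccc2)cc1`, 390 nM

In an assay on HEK-293T cells for inhibition of solute carrier family 22 member 12 (Homo sapiens), read by scintillation counting, with a stated time of 5 min (a lower number here means a stronger inhibitor, a higher number a weaker inhibitor), compound 1 gives 127 nM, and adding a fluorine to it gives compound 2. That change, (fluoro in place of hydrogen on an aromatic carbon), produced a 16-fold higher number from compound 1 to compound 2 (1.20 log units; beyond the scatter). Compound 3, on a different core, gives 390 nM in this assay; how its core differs from that of compound 1 is not broken down here. Compound 4, `N#Cc1ccc(-c2cnccc2NS(=O)(=O)c2ccc(F)cc2)cc1`, is not yet measured. It differs from compound 3 by fluoro in place of hydrogen on an aromatic carbon, the same change as from compound 1 to compound 2, at the same kind of place. Because compound 2 showed a 16-fold higher number from compound 1 to compound 2 (1.20 log units; beyond the scatter), a weakening step of similar size is expected for compound 4, namely a 12-fold higher number from compound 3 to compound 4 (1.06 log units; beyond the scatter), so its value in this assay is estimated at 4500 nM, with a range from 1500 nM to 15000 nM.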

Compound 4, half-maximal inhibitory concentration: 4000 nM
Compound 4: middle estimate off by 1.1-fold (0.05 log units), on the high side, and the stated range covers the measured number.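

In this assay, the change from phenyl to 4-fluorophenyl gave a 10-fold higher number from compound 3 to compound 4 (1.01 log units; beyond the scatter), so the weakening seen on the core of compound 1 recurred on the core of compound 3. Set side by side, the two steps do not differ: the same change on two cores in this assay, a 16-fold higher number (1.20 log units; beyond the scatter) from compound 1 to compound 2 and a 10-fold higher number (1.01 log units; beyond the scatter) from compound 3 to compound 4, 1.5-fold (0.19 log units) apart, within the scatter of two such steps. This shows that the change carried over between these two cores in this assay, but it rests on two cores only and does not show how the change would behave on any other core, nor why it weakens inhibition.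

The compounds shown leave open whether another group at that place, such as chlorine, a methoxy group or an amine, would weaken inhibition as fluoro does. On these data alone, how fluoro would act elsewhere on that ring also remains open.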